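Swapping a methoxy for a fluoro on the triazole aryl

The compounds below may be only part of what the source reports. "The series", "measured", "known", "first", "only" and "open" are said of these compounds alone.

Measured compounds:
Compound 1, `COc1ccc(/C=C\C(=O)O)c(OCc2cn(-c3ccc(NC(C)=O)cc3)nn2)c1CC=C(C)C`, 45700 nM in a functional assay on NCI-H322 cells (Homo sapiens) for cytotoxicity, read by MTT assay, with a stated time of 24 h; on this read-out lower numbers stand for stronger inhibition and higher numbers for weaker inhibition.
Compound 2, `COc1ccccc1-n1cc(COc2c(/C=C\C(=O)O)ccc(OC)c2CC=C(C)C)nn1`, 41500 nM in this assay.

Going by the values given here, compound 2 stands level with compound 1 in this assay: the only measured step, a 1.1-fold lower number from compound 1 to compound 2 (0.04 log units; within the scatter), swaps the group on the aromatic nitrogen and yields no change beyond the scatter. Compound 3, `COc1ccc(/C=C\C(=O)O)c(OCc2cn(-c3ccccc3F)nn2)c1CC=C(C)C`, differs from compound 2 by fluoro in place of methoxy on an aromatic carbon. Among the compounds with values here, that single step is the only guide, and it does not touch this exact position, so no step beyond the scatter is expected in this assay for compound 3. Compound 3 is therefore estimated at 42000 nM, with a range from 18000 nM to 100000 nM, meaning an expected step of a 1.0-fold higher number from compound 2 to compound 3 (0.01 log units; within the scatter).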

Compound 3, half-maximal inhibitory concentration: 45600 nM
Compound 3: the middle estimate sits 1.1-fold (0.04 log units) below what was measured; measured number inside the range.
By their numbers in this assay, from the lowest: compounds 2, 3 and 1 (each within the scatter of the next).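

In this assay, going from 2-methoxyphenyl to 2-fluorophenyl leaves the number unchanged within the scatter, with a 1.1-fold higher number from compound 2 to compound 3 (0.04 log units; within the scatter), so methoxy and fluoro read alike at this place on the ring. Replacing the whole 4-acetamidophenyl group with 2-fluorophenyl also gives no readable change, with a 1.0-fold lower number from compound 1 to compound 3 (0.00 log units; within the scatter), so all three aryl groups shown now stand level. Nothing available explains this flat result. Still open, going by these compounds, is whether an amine or a carboxylic acid at this place on the ring would move the number beyond the scatter. A longer chain there is equally untested by these compounds.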